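The compounds below may be only part of what the source reports. "The series", "measured", "known", "first", "only" and "open" are said of these compounds alone.

In a functional assay on MGC-803 cells (Homo sapiens) for antiproliferative activity, read by MTT assay, with a stated time of 48 h (on this read-out higher numbers stand for weaker inhibition and lower numbers for stronger inhibition), compound 1 (`COc1ccc2nc(SCC(=O)N(Cc3ccc(OC)c(O)c3)c3cc(OC)c(OC)c(OC)c3)sc2c1`) gives 71 nM and compound 2 (`COc1ccc(CN(C(=O)CSc2nc3cc(Cl)ccc3s2)c2cc(OC)c(OC)c(OC)c2)cc1O`) gives 85 nM as its result, and these two numbers lie within the scatter of each other. Compound 3 (`COc1ccc(CN(C(=O)CSc2nc3ccccc3s2)c2cc(OC)c(OC)c(OC)c2)cc1Br`) gives 852 nM in the same test, a number clearly higher than that of compound 2 and so a sign of weaker inhibition. Compound 3 differs from compound 2 in more than one place, so this gap cannot be tied to any single change.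

The next question concerns compound 4 (`COc1ccc(CN(C(=O)CSc2nc3cc(Br)ccc3s2)c2cc(OC)c(OC)c(OC)c2)cc1O`), which has not yet been measured. It differs from compound 2 by one small exchange: bromo in place of chloro on an aromatic carbon. In words, this is bromo in place of chloro on an aromatic carbon. Going by the values given here, only one measured single-place step bears on this part of the molecule. With 5-chloro-1,3-benzothiazol-2-yl in place of 6-methoxy-1,3-benzothiazol-2-yl, the result was a 1.2-fold higher number from compound 1 to compound 2 (0.08 log units; within the scatter) and the number barely moved. On the strength of that one step, no change beyond the scatter is expected in this assay on going from chloro to bromo, in either direction. The expected change is a 1.1-fold higher number from compound 2 to compound 4 (0.02 log units; within the scatter) and remains only an estimate. For compound 4 the estimated value is 90 nM (expected range 40 nM to 200 nM).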

Compound 4, half-maximal inhibitory concentration: 372 nM
Beside the measured number, compound 4's estimate is 4.1-fold (0.62 log units) below it, and the stated range ends below it.
By their numbers in this assay, from the lowest: compounds 1 and 2 (each within the scatter of the next); then compound 4; then compound 3.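

In this assay, chloro and bromo on this aromatic carbon of the six-membered aromatic ring of carbon only cannot be treated as interchangeable: exchanging one for the other gives a 4.4-fold higher number from compound 2 to compound 4 (0.64 log units; beyond the scatter), which means weaker inhibition. Going by these compounds alone, the earlier step between the methoxy and chloro groups showed only that these two groups could not be told apart, whereas the wider exchange on the sulfur now gives a 5.2-fold higher number from compound 1 to compound 4 (0.72 log units; beyond the scatter), so the group carried on the sulfur can clearly change the result, and the difference can come from a single exchange of chloro for bromo. Nothing available here explains why bromo gives a weaker result than chloro.

As far as these compounds go, it remains open whether fluoro, methyl, a nitrile or an amine on this same aromatic carbon would give a number close to that of compound 2 or close to that of compound 4. From the compounds shown here alone, it is also open whether the exchange of chloro for bromo would give a step of similar size if other parts of the molecule were different.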